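The source may hold more compounds than are shown below. What is called first, only, known or untested is meant among the compounds shown, and "the series" means these compounds.

In this account compound 1, with the structure `ClCc1cccc(Cn2cnc3c(Cl)ncnc32)c1`, serves as the starting point. In a functional assay on HCC 2998 cells (Homo sapiens) for cytotoxicity, read by sulforhodamine B assay, with a stated time of 48 h (on this read-out lower numbers stand for stronger inhibition of growth and higher numbers for weaker inhibition of growth), compound 1 gives 400 nM. Compound 2, with the structure `ClCc1cccc(Cn2cnc3c(Cl)nc(Cl)nc32)c1`, carries one further change on the shared core: chloro in place of hydrogen on an aromatic carbon. In this assay compound 2 gives 1620 nM, and the step of a 4.1-fold higher number from compound 1 to compound 2 (0.61 log units; beyond the scatter) shows that this single exchange was accompanied by a clearly weaker inhibition of growth.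

Compound 3, with the structure `ClCc1ccccc1Cn1cnc2ncnc(Cl)c21`, is built from the same atoms as compound 1 joined differently; the difference between the two cores is not broken down here. In this assay compound 3 gives 2230 nM, the highest of the three numbers; it sits within the usual scatter of compound 2 and beyond it from compound 1.

Compound 4, with the structure `ClCc1ccccc1Cn1cnc2nc(Cl)nc(Cl)c21`, has not yet been measured. It stands to compound 3 as compound 2 stands to compound 1, the change being (chloro in place of hydrogen on an aromatic carbon); the surroundings of the new chloro group are described in the same words for both pairs, so the change is the same one made a second time. For the measured compounds named here, the expected step of a 2.9-fold higher number from compound 3 to compound 4 (0.46 log units; beyond the scatter) rests on the single earlier instance of this change, the step of a 4.1-fold higher number from compound 1 to compound 2 (0.61 log units; beyond the scatter), softened somewhat because compound 3 already starts from 2230 nM and only one precedent is available. For compound 4 in this assay the estimated value is therefore 6500 nM, with a plausible range from 2500 nM to 16000 nM.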

Compound 4, concentration for 50% growth inhibition: 18600 nM
For compound 4 the middle estimate is 2.9-fold (0.46 log units) below the measured one; the measured number lies above the stated range.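

In this assay, exchanging hydrogen for chloro on the aromatic ring gives an 8.3-fold higher number from compound 3 to compound 4 (0.92 log units; beyond the scatter), which is again a weaker inhibition of growth, as the same change gave on the core of compound 1. The two steps point the same way, and the gap between their sizes gives no ground for calling one larger than the other: the same change on two cores in this assay, a 4.1-fold higher number (0.61 log units; beyond the scatter) from compound 1 to compound 2 and an 8.3-fold higher number (0.92 log units; beyond the scatter) from compound 3 to compound 4, 2.1-fold (0.31 log units) apart, within the scatter of two such steps This shows that, on these two cores, the change carried over in direction and in a size that cannot be told apart, but two pairs from a single cell assay do not establish a rule for other cores in the series, and they do not show why the growth inhibition weakens.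

The compounds shown leave open what other groups would do at this aromatic carbon, since only hydrogen and chloro appear there, and an amine, a methoxy group or a methyl group could follow the chloro group or part from it. They also leave open whether the same step would hold if the chloromethyl group were exchanged for a hydroxymethyl group, or in other cell lines.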